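A Trifluoromethyl for Methyl Swap on a Chalcone

The source may hold more compounds than are shown below. What is called first, only, known or untested is meant among the compounds shown, and "the series" means these compounds.

Compound 1 `CCOc1ccc(C(=O)/C=C/c2ccc(C)cc2)cc1` is tested in an assay on isolated protein for inhibition of Amine oxidase [flavin-containing] B (Homo sapiens) (on this read-out higher numbers stand for weaker inhibition and lower numbers for stronger inhibition), where compound 1 gives 210 nM. Going by the values given here, this is the only number reported for the two measured compounds. Compound 2 `COc1ccc(/C=C/C(=O)c2ccc(ON=C3CCCCC3)cc2)cc1` is reported in this assay only as a limit, < 300 nM. Of the two values shown, one sits at the limit of < 300 nM in this assay, at which 1 of the 2 values shown sits, so compound 1 stands alone as a measured number and cannot be ranked against anything.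

Compound 3 `CCOc1ccc(C(=O)/C=C/c2ccc(C(F)(F)F)cc2)cc1` differs from compound 1 by trifluoromethyl in place of methyl on an aromatic carbon. Among the compounds with values here, no measured pair separates this change, so its size rests on expectation alone. The step from compound 1 to compound 3 is expected to be small, a 1.4-fold lower number from compound 1 to compound 3 (0.15 log units; within the scatter), leaning toward stronger inhibition but not clearly beyond the usual scatter. Compound 3 is therefore estimated at 150 nM, with a range from 50 nM to 600 nM.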

Compound 3, half-maximal inhibitory concentration: 210 nM
For compound 3 the middle estimate is 1.4-fold (0.15 log units) below the measured one; measured number inside the range.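

Going by these compounds alone, the step from methyl to trifluoromethyl gives this series its first measured pair, and with it the first direct reading at this position. In this assay, trifluoromethyl in place of methyl on an aromatic carbon, para to a large group, gives no change at the digits printed from compound 1 to compound 3 (within the scatter). Trifluoromethyl has 4 heavy atoms where methyl has 1, so on this read-out the position tolerates this larger group with no shift beyond the scatter, and no measured property shown here accounts for that outcome.

On these data alone, whether a group of another kind at this position, such as an amine or a carboxylic acid, would also leave the number in place remains open. A single pair also cannot show whether the same swap would behave alike on another core.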